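This account rests on a few compounds, and the source may have more. Where it says the series, first, only, none or still open, it means among the compounds named here.

Compound 1 `COc1ccc(CNc2nc3cc(N)cc(N)c3nc2-c2ccccc2)cc1OC` is one of two measured members of a small series built on a shared core. Going by the values given here, in a functional assay on U-251 cells (Homo sapiens) for inhibition, read by sulforhodamine B assay, with a stated time of 48 h (a higher number here means a weaker inhibitor of growth, a lower number a stronger inhibitor of growth), compound 1 gives 38900 nM, the only true number in this set. Compound 2 `CCOC(=O)[C@H](CCC(=O)O)NC(=O)c1ccc(Sc2nc3cc(N)cc(N)c3nc2-c2ccccc2)cc1` returns a limit of the assay rather than a number: in this assay compound 2 gives < 100000 nM. Among the compounds with values here, compound 2 thus sits at the limit of < 100000 nM in this assay, at which 1 of the 2 values shown sits, so no step between two measured compounds is known here. Compound 3 `COc1cc(CNc2nc3cc(N)cc(N)c3nc2-c2ccccc2)cc(OC)c1OC` has not yet been measured. It differs from compound 1 by methoxy in place of hydrogen on an aromatic carbon, that is, a methoxy in place of hydrogen on an aromatic carbon. Within the data shown here, with no measured step to draw on, the step of a 1.3-fold lower number from compound 1 to compound 3 (0.11 log units; within the scatter) is expected to be small, within the scatter of repeats, and in no firm direction. Compound 3 is therefore estimated to give 30000 nM in this assay, with a range from 10000 nM to 100000 nM.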

Compound 3, concentration for total growth inhibition: 6310 nM
Compound 3: the middle estimate sits 4.8-fold (0.68 log units) above what was measured; measured number below the stated range.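

In this assay, placing a methoxy in place of hydrogen on an aromatic carbon, ortho to a methoxy group and meta to a large group, gives a 6.2-fold lower number from compound 1 to compound 3 (0.79 log units; beyond the scatter). Going by these compounds alone, this is the first step in the set that can be read between two measured compounds, and it shows that this position is not indifferent: one added methoxy, with the rest of the molecule unchanged, moves the compound towards stronger inhibition of growth. Nothing shown here accounts for the size or direction of this step.

On these data alone, only hydrogen and methoxy are compared at this position, so it remains open whether a hydroxyl, a fluorine or a longer ethoxy there would give a similar step. As far as these compounds go, it also remains open whether the added methoxy would have the same effect on a different core.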